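The compounds below may be only part of what the source reports. "The series", "measured", "known", "first", "only" and "open" are said of these compounds alone.

Compound 1, `COc1cc(-n2c(-c3ccc(Br)cc3)csc2=S)cc(OC)c1OC`, reaches in a functional assay on T47D cells (Homo sapiens) for cytotoxicity, read by MTT assay, with a stated time of 48 h (on this read-out higher numbers stand for weaker inhibition and lower numbers for stronger inhibition), only a limit, > 100 ug/mL.
Compound 2, `COc1cc(-n2c(-c3ccc(Cl)cc3)csc2=S)cc(OC)c1OC`, reaches in this assay only a limit, > 100 ug/mL.
Compound 3, `COc1cc(-n2c(-c3ccc(C)cc3)csc2=S)cc(OC)c1OC`, gives in this assay 16.3 ug/mL.

Among the measured compounds shown here, compound 3 thus stands alone as the one compound with a read number; the other two values are limits, as the limit of > 100 ug/mL in this assay, at which 2 of the 3 values shown sit, records. Compound 4, `COc1cc(-n2c(-c3ccc(-c4ccccc4)cc3)csc2=S)cc(OC)c1OC`, differs from compound 3 by phenyl in place of methyl on an aromatic carbon. For the measured compounds named here, no measured step swaps methyl for phenyl. The steps that come nearest both end at compound 3: an at least 6.1-fold lower number from compound 1 to compound 3 (0.78 log units; beyond the scatter) and an at least 6.1-fold lower number from compound 2 to compound 3 (0.78 log units; beyond the scatter), each a halogen giving way to methyl. They show that the group on this aromatic carbon can shift the read-out by at least a modest amount, yet they give no direction for a larger carbon group entering in place of methyl. The expected step is therefore of uncertain direction, a 1.8-fold higher number from compound 3 to compound 4 (0.26 log units; within the scatter), and carries a wide range. Compound 4 is expected to give about 30 ug/mL in this assay, between 8 ug/mL and 150 ug/mL.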

Compound 4, half-maximal inhibitory concentration: > 100 ug/mL
Compound 4: no number, only a limit (the forecaster's own chance of this, stated with the estimate: 30%); middle value at least 3.3-fold (0.52 log units) away from the limit.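

In this assay, phenyl in place of methyl on this aromatic carbon gives an at least 6.1-fold higher number from compound 3 to compound 4 (0.78 log units; beyond the scatter), so the earlier finding that the group here can shift the read-out now has a direction for a larger carbon group: towards weaker inhibition. The steps from compound 1 to compound 4 and from compound 2 to compound 4 cannot be read, as both ends of each are limits. Compound 3, with methyl, remains the only compound with a read number, while compound 1, compound 2 and compound 4 all reach only a limit: the limit of > 100 ug/mL in this assay, at which 3 of the 4 values shown sit.

On these data alone, how compound 1, compound 2 and compound 4 order among themselves stays open. Also open, as far as these compounds go, is whether ethyl, methoxy or an amine on this carbon would give a read number, and whether that number would lie lower than that of compound 3.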